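A Side-Chain Rearrangement Expected to Leave Potency Unchanged

The compounds below may be only part of what the source reports. "The series", "measured", "known", "first", "only" and "open" are said of these compounds alone.

Compound 2 `C=C[C@@](C)(O)CC[C@H]1C(=C)CC[C@@H]2[C@]1(C)CCC[C@]2(C)C(=O)O` is one of three compounds tested in a functional assay on SW480 cells (Homo sapiens) for cytotoxicity, read by MTT assay, with a stated time of 48 h; a lower number here means a stronger inhibitor, a higher number a weaker inhibitor. For compound 2 this assay reports only a limit, > 40000 nM. Compound 3 `C=C1CC[C@@H]2[C@](C)(CCC[C@@]2(C)C(=O)O)[C@H]1CC/C(C)=C/COC(C)=O` also reaches only a limit in this assay, > 40000 nM. Within the data shown here, compound 1 `C=CC(=C)CC[C@@H]1[C@@]2(C)CCC[C@](C)(COC(=O)/C=C/c3ccc(O)c(OC)c3)[C@@H]2CC[C@@]1(C)O`, in which an ester-linked side chain replaces the carboxylic acid, gives 16900 nM in this assay, the single numerical value among the three. Compound 2 thus stands at the weak end of what has been measured, alongside compound 3, as summarised by the limit of > 40000 nM in this assay, at which 2 of the 3 values shown sit.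

Compound 4 `C=CC(=C)[C@H](O)C[C@H]1C(=C)CC[C@@H]2[C@]1(C)CCC[C@]2(C)C(=O)O` differs from compound 2 only in the side chain: a group of 6 heavy atoms (5 carbon, 1 oxygen; no ring) in place of a group of 6 heavy atoms (5 carbon, 1 oxygen; no ring), on a saturated chain carbon bound to a saturated ring carbon. Among the measured compounds shown here, no pair of measured compounds shows a change of this kind, so its size is not anchored by any measured step. Since the entering group matches the leaving group in what is counted, differing only in the second double bond, a step no larger than the scatter is expected, in no particular direction. The step of a number no higher from compound 2 to compound 4 (the limit leaves the size open) is therefore estimated to be essentially none. Compound 4 is expected to give about 40000 nM in this assay, within a range from 20000 nM to 80000 nM, and most probably again only a limit.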

Compound 4, half-maximal inhibitory concentration: > 40000 nM
Compound 4: no number, only a limit; the forecaster's own chance of this, stated with the estimate: 70%; the middle value lies on the limit itself.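

Compound 2 and compound 4 each reach only a limit in this assay, and the step between them cannot be read. The compounds shown leave open whether the side chain of compound 4, with its second double bond, changes potency relative to that of compound 2 at all.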